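Amide to sulfonamide swap on the shared core

The source may hold more compounds than are shown below. What is called first, only, known or untested is meant among the compounds shown, and "the series" means these compounds.

Compound 1 `CC1CC1C(=O)N1CCc2nc(C#Cc3ccccc3)sc2C1` and compound 2 `Cc1nc(C(=O)N2CCc3nc(C#Cc4ccccc4)sc3C2)cs1` share a core bearing a phenylethynyl group. In an assay on HEK293 cells for negative allosteric modulation of metabotropic glutamate receptor 5 (Homo sapiens), read by FLIPR, with a stated time of 1 h (a higher number here means a weaker inhibitor, a lower number a stronger inhibitor), compound 1 gives > 10000 nM, a limit of the assay and not a number. In this assay compound 2 likewise gives > 10000 nM, also a limit. Within the data shown here, the single measured step, a step that the two limits leave unreadable from compound 1 to compound 2, stays unreadable, since both values sit at the limit (the limit of > 10000 nM in this assay, at which 2 of the 2 values shown sit). Compound 3 `O=S(=O)(C1CC1)N1CCc2nc(C#Cc3ccccc3)sc2C1` differs from compound 2 by cyclopropylsulfonyl in place of (2-methyl-1,3-thiazol-4-yl)carbonyl on an amine nitrogen in a ring. No readable step bears on this change. Compound 3 is expected at 15000 nM, range 4000 nM to 60000 nM, most probably again reported as a limit. The expected step that the limit leaves unreadable from compound 2 to compound 3 cannot be called a change beyond the scatter.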

Compound 3, half-maximal inhibitory concentration: 34 nM
The estimate for compound 3 lay 440-fold (2.64 log units) above the measured number; measured number outside the range, below it.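

On the amine nitrogen in a ring, the position proves able to carry a large change in this assay. Cyclopropylsulfonyl gives an at least 290-fold lower number from compound 2 to compound 3 (2.46 log units; beyond the scatter) and also an at least 290-fold lower number from compound 1 to compound 3 (2.46 log units; beyond the scatter), so the result holds against both an aromatic and a non-aromatic group on a carbonyl. The step between the two carbonyl compounds cannot be read, and compound 3 alone stands clear of the limit: the limit of > 10000 nM in this assay, at which 2 of the 3 values shown sit.

This change replaces the carbonyl and the group on it together, and the compounds shown do not separate the two. On these data alone, how a cyclopropylcarbonyl, methylsulfonyl or phenylsulfonyl group on that nitrogen would read stays open.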